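The source may report more compounds than this note shows. Statements on the series, on what has been measured and on what is new or still open speak of the compounds shown alone.

Measured compounds in an ADME assay on NHDF cells (Homo sapiens) for cytotoxicity, read by MTT assay, with a stated time of 72 h; a lower number here means a stronger inhibitor, a higher number a weaker inhibitor:
- Compound 1 `COc1cccc(/C=C2\CCC/C(=C\c3ccccc3Br)C2=O)c1OC` gives > 50000 nM, which is a limit of this assay rather than a number.
- Compound 2 `COc1cccc(/C=C2\CCC/C(=C\c3ccc(Br)cc3)C2=O)c1OC` gives 21400 nM.
- Compound 3 `COc1cccc(/C=C2\CCC/C(=C\c3ccc(O)cc3)C2=O)c1OC` gives > 50000 nM, again a limit of this assay and not a number.

Among the compounds with values here, compound 2 stands alone in this set as the only compound with a measured number; the other two values are limits (the limit of > 50000 nM in this assay, at which 2 of the 3 values shown sit). Among the measured steps, the change of 4-bromophenyl in place of 2-bromophenyl gave an at least 2.3-fold lower number from compound 1 to compound 2 (0.36 log units; beyond the scatter), while hydroxy in place of bromo on an aromatic carbon gave an at least 2.3-fold higher number from compound 2 to compound 3 (0.36 log units; beyond the scatter). The step from compound 1 to compound 3 is a step that the two limits leave unreadable from compound 1 to compound 3.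

The step to be followed goes from compound 2 to the unmeasured compound 4 `COc1cc(/C=C2\CCC/C(=C\c3cccc(OC)c3OC)C2=O)ccc1O`. The change is 4-hydroxy-3-methoxyphenyl in place of 4-bromophenyl on a double-bonded chain carbon bound to a double-bonded ring carbon. Within the data shown here, the step that bears most directly on it is the one from compound 2 to compound 3, where hydroxy replaced bromo, since compound 4 also carries a hydroxy group at the same ring while adding a methoxy group. That step was at least modest and toward a higher number in this assay, so a step of similar size and direction is expected here, with a fair chance that only a limit is reported. Compound 4 is therefore estimated at 50000 nM, within 20000 nM to 150000 nM, meaning an expected step of a 2.3-fold higher number from compound 2 to compound 4 (0.37 log units; beyond the scatter).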

Compound 4, half-maximal inhibitory concentration: 14300 nM
Compound 4: middle estimate off by 3.5-fold (0.54 log units), on the high side; measured number outside the range, below it.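

In this assay, 4-hydroxy-3-methoxyphenyl in place of 4-bromophenyl on this chain carbon gives a 1.5-fold lower number from compound 2 to compound 4 (0.18 log units; within the scatter), so the result is within the scatter and the two groups cannot be told apart here, although they differ in size and in their hydrogen-bond donors and acceptors. Adding a methoxy group in place of hydrogen on the ring of the 4-hydroxyphenyl compound gives an at least 3.4-fold lower number from compound 3 to compound 4 (0.54 log units; beyond the scatter), which the earlier compounds could not show: a hydroxy group on this ring need not leave the value at the limit of the assay, and one added methoxy group is enough to bring it back to a measured number. The same group, set against 2-bromophenyl, gives an at least 3.4-fold lower number from compound 1 to compound 4 (0.54 log units; beyond the scatter), but this step and the one before it each start from a limit rather than a number, so their true sizes stay unknown: the limit of > 50000 nM in this assay, at which 2 of the 4 values shown sit.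

As far as these compounds go, it remains open whether a methoxy group alone on this ring, without the hydroxy group, would behave like 4-hydroxy-3-methoxyphenyl. Also unknown is how this assay would respond to an amine or a carboxylic acid on the same ring.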